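Butyl ester in place of the free acid

A few compounds are considered here, and "the series" means these few. Any claim that something is new, unique, unknown or untested is made for them only; others in the source may bear on it.

Compound 3 `CCOc1ccc(-c2cccc(C(=O)O)c2)cc1` carries a carboxy group on the shared core. In an assay on COS-7 cells for inhibition of patatin-like phospholipase domain-containing protein 2 (Mus musculus) (a lower number here means a stronger inhibitor, a higher number a weaker inhibitor), compound 3 gives only a limit, > 200000 nM, and no number (the limit of > 200000 nM in this assay, at which 1 of the 3 values shown sits). Its ethyl ester, compound 1 `CCOC(=O)c1cccc(-c2ccc(OCC)cc2)c1`, gives 50000 nM, and the dimethylsulfamoyl analogue compound 2 `CCOc1ccc(-c2cccc(S(=O)(=O)N(C)C)c2)cc1` gives 110000 nM. The measured steps read an at least 4.0-fold higher number from compound 1 to compound 3 (0.60 log units; beyond the scatter) and an at least 1.8-fold higher number from compound 2 to compound 3 (0.25 log units; that floor lies within the scatter). Compound 4 `CCCCOC(=O)c1cccc(-c2ccc(OCC)cc2)c1` differs from compound 3 by butyl in place of hydrogen on an oxygen next to a carbonyl group. The step that bears on this change is the reverse of the one from ethyl ester to acid, an at least 4.0-fold higher number from compound 1 to compound 3 (0.60 log units; beyond the scatter). For compound 4 a step of at least that size, toward a lower number, is expected, an at least 5.0-fold lower number from compound 3 to compound 4 (0.69 log units; beyond the scatter). Compound 4 is estimated at 40000 nM, between 10000 nM and 150000 nM.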

Compound 4, half-maximal inhibitory concentration: 100000 nM
Estimate against measurement, compound 4: 2.5-fold (0.40 log units) below; the measured number falls inside the stated range.
By their numbers in this assay, from the lowest: compounds 1, 4 and 2 (each within the scatter of the next, the first and the last beyond it). At a limit, above all of these: compound 3.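

In this assay the ethyl and butyl esters cannot be told apart, with a 2.0-fold higher number from compound 1 to compound 4 (0.30 log units; within the scatter) between them, and the butyl ester likewise cannot be told from the dimethylsulfamoyl analogue, with a 1.1-fold lower number from compound 2 to compound 4 (0.04 log units; within the scatter) between them. The step from the free acid, an at least 2.0-fold lower number from compound 3 to compound 4 (0.30 log units; that floor lies within the scatter), is only a floor and rests on a limit: the limit of > 200000 nM in this assay, at which 1 of the 4 values shown sits.

The compounds shown leave open whether an ester with a longer chain than butyl, or an amide in place of the ester, would separate from these values.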